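Benzyloxy to 5-fluoro-2-hydroxyphenyl: notes on the series

The compounds below may be only part of what the source reports. "The series", "measured", "known", "first", "only" and "open" are said of these compounds alone.

Of the compounds shown here, two on the shared core have been measured so far. In a functional assay on V79-379A cells (Cricetulus griseus) for cytotoxicity, read by MTT assay, in the presence of a further agent that is not named here (on this read-out lower numbers stand for stronger inhibition and higher numbers for weaker inhibition), compound 1 `COC1=CC(=O)c2c(c(COC(=O)c3ccc(F)cc3)c(C)n2C)C1=O` gives 300 nM, while compound 2 `COC1=CC(=O)c2c(c(COCc3ccccc3)c(C)n2C)C1=O` gives 410000 nM. Compound 2 therefore holds the higher of the two numbers, far beyond the scatter from compound 1, and is the weaker inhibitor on this read-out.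

The next compound is compound 3 `COC1=CC(=O)c2c(c(Cc3cc(F)ccc3O)c(C)n2C)C1=O`, which carries 5-fluoro-2-hydroxyphenyl in place of benzyloxy on a saturated chain carbon bound to an aromatic carbon. For the measured compounds named here, no measured step covers this change, so the expectation is loosely founded. Compound 1 at 300 nM shows that this core can reach much lower numbers, and compound 2 at 410000 nM marks the high end seen so far, so movement downward is the more likely direction. The expected change in this assay is a sizeable step toward stronger inhibition, estimated as a 10-fold lower number from compound 2 to compound 3 (1.01 log units; beyond the scatter). For compound 3 the estimated value is 40000 nM, with an expected range of 3000 nM to 400000 nM.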

Compound 3, half-maximal inhibitory concentration: 110000 nM
Beside the measured number, compound 3's estimate is 2.8-fold (0.44 log units) below it; the range from low to high includes it.
By their numbers in this assay, from the lowest: compound 1; then compound 3; then compound 2.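

In this assay, for the compounds shown here, this is the first measured change at this place, a saturated chain carbon bound to an aromatic carbon: 5-fluoro-2-hydroxyphenyl in place of benzyloxy gives a 3.7-fold lower number from compound 2 to compound 3 (0.57 log units; beyond the scatter) as a modest step. The two groups match in heavy-atom count and each holds one six-membered aromatic ring of carbon only, yet the entering group carries fluorine and a hydrogen-bond donor that benzyloxy lacks, so the number at this place responds to a swap that leaves the size of the group unchanged. Even so, compound 3 at 110000 nM remains far from compound 1 at 300 nM on the printed values, so this replacement does not reach the low end seen on the shared core. No data at hand bear on the cause of this step.

The compounds shown do not separate the share of the hydroxy group, the fluorine and the lost chain oxygen in this step. Also open, on these data alone, is how an amine or a carboxylic acid at this place would read in this assay on the same core.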